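The source may report more compounds than this note shows. Statements on the series, on what has been measured and on what is new or still open speak of the compounds shown alone.

Measured so far in a functional assay on EC9706 cells (Homo sapiens) for cytotoxicity, read by MTT assay, with a stated time of 72 h; on this read-out higher numbers stand for weaker inhibition and lower numbers for stronger inhibition:
- compound 1, `O=C(CSC(=S)N[C@H]1CCOC1=O)Nc1cccc(Cl)c1`: 107000 nM
- compound 2, `O=C(CSC(=S)N[C@H]1CCOC1=O)Nc1ccc(Cl)cc1Cl`: > 128000 nM, a limit of the assay, not a number
- compound 3, `CCSC(=S)N[C@H]1CCOC1=O`: > 128000 nM, a limit of the assay, not a number

Compound 3 thus stands at the top of the measured range, described only by the limit of > 128000 nM in this assay, at which 2 of the 3 values shown sit. Compound 4, `CCCCCCSC(=S)N[C@H]1CCOC1=O`, differs from compound 3 by butyl in place of hydrogen on a saturated chain carbon, two bonds along the chain from a sulfur. Going by the values given here, no measured pair in this assay differs in one place, so no measured step gives a size for this change; with compound 3 at a limit, no step beyond the usual scatter is expected in either direction. The estimate for compound 4 in this assay is 110000 nM, with a range of 40000 nM to 300000 nM. For compound 4 the expected step is an at least 1.1-fold lower number from compound 3 to compound 4 (0.06 log units; that floor lies within the scatter), essentially none.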

Compound 4, half-maximal inhibitory concentration: > 128000 nM
Compound 4: a limit, no number (the forecaster's own chance of this, stated with the estimate: 60%); middle value at least 1.1-fold (0.06 log units) away from the limit.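

Compound 3 and compound 4 both stand only as limits, not numbers, in this assay, so no step between them can be read: the limit of > 128000 nM in this assay, at which 3 of the 4 values shown sit.

Going by these compounds, whether butyl in place of hydrogen changes the read-out at all remains open.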